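This account rests on a few compounds, and the source may have more. Where it says the series, first, only, none or still open, it means among the compounds named here.

Two acyl hydrazones have been run in an ADME assay on cells (Homo sapiens) for antiproliferative activity, read by MTT assay (on this read-out higher numbers stand for weaker inhibition and lower numbers for stronger inhibition), so far. Compound 1, `C/C(=N\NC(=O)c1ccc(C(F)(F)F)cc1)c1cnccn1`, gives 1160 nM. Compound 2, `O=C(NN=C(c1ccccn1)c1ccccn1)c1ccncc1`, gives 830 nM. Compound 2 has the lower of the two numbers, but compound 1 sits within the usual scatter of it, so the two cannot be told apart on this evidence, and they share no single point of difference that would make a clean step.

The next compound to be measured is compound 3, `O=C(NN=C(c1ccccn1)c1ccccn1)c1ccc(O)cc1`. Compared with compound 2, the change is 4-hydroxyphenyl in place of pyridin-4-yl on a carbonyl carbon. The rest of the molecule, the hydrazone carrying two pyridin-2-yl groups, is kept as it is.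

Among the measured compounds shown here, no measured pair in this set shows what such an exchange does, so the expectation rests only on the two numbers above. Compound 3 is expected to stay close to compound 2, with no step beyond the scatter in either direction, which is what a 1.1-fold higher number from compound 2 to compound 3 (0.04 log units; within the scatter) is meant to express. On that basis compound 3 is estimated at 900 nM in this assay, in a range from 300 nM to 2700 nM.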

Compound 3, half-maximal inhibitory concentration: 7530 nM
The estimate for compound 3 lay 8.4-fold (0.92 log units) below the measured number; measured number above the stated range.
By their numbers in this assay, from the lowest: compounds 2 and 1 (each within the scatter of the next); then compound 3.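

In this assay, among the compounds shown here, putting 4-hydroxyphenyl in place of pyridin-4-yl on the carbonyl carbon, with the hydrazone carrying two pyridin-2-yl groups kept as it is, gives a 9.1-fold higher number from compound 2 to compound 3 (0.96 log units; beyond the scatter), the first step in this set and one that lies beyond the scatter, so the group on this carbonyl carbon does move the number. The exchange alters two things at once: the group that leaves has a hetero atom in its ring and no hydrogen-bond donor, while the group that enters has a ring of carbon only and carries a hydrogen-bond donor, and this single step cannot separate the two. No measurement at hand speaks to the reason for the step.

The compounds shown leave open whether the higher number goes with the loss of the ring nitrogen or with the arrival of the hydroxyl; a plain phenyl group or a 4-methoxyphenyl group on this carbonyl carbon would speak to that. They also leave open how an amine or a carboxylic acid in the place of that hydroxyl would read in this assay, and whether the same exchange gives a similar step on the core of compound 1.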